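Compound 3 to compound 4: fluoro in place of methyl

A few compounds are considered here, and "the series" means these few. Any claim that something is new, unique, unknown or untested is made for them only; others in the source may bear on it.

- compound 1 `Nc1nc2cc(Cl)c(Cl)cc2n1Cc1ccc(F)cc1`: 30000 nM
- compound 2 `Clc1ccc(Cn2c(Br)nc3cc(Cl)c(Cl)cc32)cc1`: > 100000 nM (a limit)
- compound 3 `Cc1ccc(Cn2c(Br)nc3cc(Cl)c(Cl)cc32)cc1`: > 100000 nM (a limit)

In a functional assay on CEM-SS cells (Homo sapiens) for cytotoxicity (on this read-out lower numbers stand for stronger inhibition and higher numbers for weaker inhibition), compound 3 gives only a limit, > 100000 nM, and no number. Compound 4 `Fc1ccc(Cn2c(Br)nc3cc(Cl)c(Cl)cc32)cc1` comes from compound 3 by fluoro in place of methyl on an aromatic carbon, para to a large group. Going by the values given here, the one measured step at this place is a step that the two limits leave unreadable from compound 2 to compound 3, so it gives no size to carry over. What remains is the limit of > 100000 nM in this assay, at which 2 of the 3 values shown sit. No step beyond the scatter is expected in this assay, and a further limit is the likeliest report. The estimated step is a number no higher from compound 3 to compound 4 (the limit leaves the size open). For compound 4 the expected value is 100000 nM, with an estimated range of 50000 nM to 200000 nM.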

Compound 4, half-maximal inhibitory concentration: > 100000 nM
Compound 4 ended at the assay's limit (the forecaster's own chance of this, stated with the estimate: 80%); the middle value lies on the limit itself.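

With fluoro, the aromatic carbon para to a large group has now carried chloro, methyl and fluoro in the bromo compounds, and in this assay none of the three gives a number, only a limit; the steps among compound 2, compound 3 and compound 4 cannot be read. Going by these compounds alone, the one readable step lies at the other place, bromo in place of amino: an at least 3.3-fold higher number from compound 1 to compound 4 (0.52 log units; beyond the scatter). The limit now dominates the values shown: the limit of > 100000 nM in this assay, at which 3 of the 4 values shown sit.

On these data alone, how far these three bromo compounds lie past the limit stays unknown. As far as these compounds go, whether an amine or a carboxylic acid at the fluoro position would give a number also stays open.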